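The source may report more compounds than this note shows. Statements on the series, on what has been measured and on what is new or still open speak of the compounds shown alone.

Measured in a functional assay on ECa-109 cells for inhibition, with ECa-109 cell line (Homo sapiens) as the target, read by sulforhodamine B assay; a lower number here means a stronger inhibitor, a higher number a weaker inhibitor:
- compound 1 `O=C1C=C(NC2CCCCC2)C(=O)c2c1nc1n2[C@H]2OC[C@@H](O)[C@H]2OC1`: > 16000 nM (a limit of the assay)
- compound 2 `O=C1C=C(Nc2ccc(Br)cc2)C(=O)c2c1nc1n2[C@H]2OC[C@@H](O)[C@H]2OC1`: 2850 nM
- compound 3 `O=C1C=C(Nc2ccccc2)C(=O)c2c1nc1n2[C@H]2OC[C@@H](O)[C@H]2OC1`: 4970 nM

Compound 3, at 4970 nM, cannot be told apart from its bromo analogue, given a 1.7-fold higher number from compound 2 to compound 3 (0.24 log units; within the scatter). Compound 4 `O=C1C=C(N2CCCC2)C(=O)c2c1nc1n2[C@H]2OC[C@@H](O)[C@H]2OC1` carries pyrrolidin-1-yl in place of anilino on a double-bonded ring carbon. The nearest measured evidence is an at least 3.2-fold lower number from compound 1 to compound 3 (0.50 log units; beyond the scatter), with phenyl in place of cyclohexyl on an amine nitrogen, and an at least 5.6-fold lower number from compound 1 to compound 2 (0.74 log units; beyond the scatter) points the same way. Read in reverse, these steps suggest a higher number in this assay when the aromatic ring leaves. Pyrrolidin-1-yl is not cyclohexyl, however, so they transfer only loosely. The expected change is modest, at a 1.8-fold higher number from compound 3 to compound 4 (0.26 log units; within the scatter). For compound 4 the estimate is 9000 nM, with an expected range from 2500 nM to 30000 nM.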

Compound 4, half-maximal inhibitory concentration: > 16000 nM
Compound 4 ended at the assay's limit (the forecaster's own chance of this, stated with the estimate: 30%); middle value at least 1.7-fold (0.24 log units) from the limit.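

Replacing anilino with pyrrolidin-1-yl on the double-bonded ring carbon weakens the compound in this assay, with an at least 3.2-fold higher number from compound 3 to compound 4 (0.50 log units; beyond the scatter), and the bromo analogue gives an at least 5.6-fold higher number from compound 2 to compound 4 (0.74 log units; beyond the scatter). Both compounds with a non-aromatic ring here now fall short of the two aryl compounds, whether or not the amine hydrogen stays. The step between compound 1 and compound 4 cannot be read, since both values are limits: the limit of > 16000 nM in this assay, at which 2 of the 4 values shown sit.

Going by these compounds, in compound 4 the aromatic ring and the amine hydrogen leave together, so their separate shares stay open. An N-methylanilino or benzylamino group at this position remains untested among the compounds shown.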